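The compounds below may be only part of what the source reports. "The series", "measured", "known", "first", "only" and "open" are said of these compounds alone.

Measured in a functional assay on GC3/MTK- cells (Homo sapiens) for inhibition; a lower number here means a stronger inhibitor, a higher number a weaker inhibitor:
- compound 1 `C#CCN(Cc1ccc2nc(C)nc(O)c2c1)c1cccc(CC)c1` gives 5000 nM
- compound 2 `C#CCN(Cc1ccc2nc(C)nc(O)c2c1)c1ccc(S(=O)(=O)C(F)(F)F)cc1` gives 2750 nM

Among the measured compounds shown here, these two values lie within the scatter of each other, so compound 2 does not stand apart from compound 1 on the numbers so far. Compound 3 `C#CCN(Cc1ccc2nc(C)nc(O)c2c1)c1ccc(S(=O)(=O)N2CCNCC2)cc1` keeps the rest of compound 2 but has piperazin-1-yl in place of trifluoromethyl on a sulfonyl sulfur and remains to be measured. For the measured compounds named here, no measured pair shows this change, so no step beyond the scatter is expected in this assay and the estimated step is a 1.3-fold higher number from compound 2 to compound 3 (0.10 log units; within the scatter) in size. Compound 3 is estimated at 3500 nM with an expected range of 900 nM to 13000 nM in this read-out.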

Compound 3, half-maximal inhibitory concentration: > 50000 nM
Compound 3 ended at the assay's limit; the forecaster's own chance of this, stated with the estimate: 15%; middle value at least 14-fold (1.15 log units) away from the limit.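

In this assay, the group on the sulfonyl sulfur proves able to shift the read-out: piperazin-1-yl in place of trifluoromethyl gives an at least 18-fold higher number from compound 2 to compound 3 (1.25 log units; beyond the scatter), the only step shown here. Compound 3 gives > 50000 nM, which is a limit of the assay, so this step has a lower bound and no exact size: the limit of > 50000 nM in this assay, at which 1 of the 3 values shown sits.

From the compounds shown here alone, it remains open whether a sulfonyl sulfur carrying morpholin-4-yl or dimethylamino would read like compound 2 or like compound 3. Going by these compounds, the effect of capping the ring amine of piperazin-1-yl with an acetyl group also remains open.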